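The compounds below may be only part of what the source reports. "The series", "measured", "known", "first", "only" and "open" are said of these compounds alone.

Compound 2, `CCCCCN[C@@H]1C=C[C@H](O)[C@H](O)[C@H]1O`, gives the lowest number of the three measured compounds in an assay for inhibition of beta-galactosidase (Homo sapiens), read by fluorescence, with a stated time of 30 min, at pH 4.5; on this read-out lower numbers stand for stronger inhibition and higher numbers for weaker inhibition; in that assay compound 2 gives 19000 nM. Compound 1, `CCCCCCCCN[C@@H]1C=C[C@H](O)[C@H](O)[C@H]1O`, gives 120000 nM, and compound 3, `CCCCCCCCCCN[C@@H]1C=C[C@H](O)[C@H](O)[C@H]1O`, gives 43000 nM. The steps among them are all modest: a 6.3-fold lower number from compound 1 to compound 2 (0.80 log units; beyond the scatter), a 2.8-fold lower number from compound 1 to compound 3 (0.45 log units; beyond the scatter), and a 2.3-fold higher number from compound 2 to compound 3 (0.35 log units; beyond the scatter). The chain on the amine nitrogen has thus been varied in length alone, and the numbers do not move in one direction with length, since compound 3 sits between compound 2 and compound 1.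

Compound 4, `CC(C)CN[C@@H]1C=C[C@H](O)[C@H](O)[C@H]1O`, differs from compound 2 by isopropyl in place of butyl on a saturated chain carbon bound to an amine nitrogen. Going by the values given here, none of the measured steps shows a branched chain, so the bearing of the earlier steps is indirect: they show that changes of a few carbons on this chain shift the number only modestly. It is therefore expected that the step of a 1.6-fold higher number from compound 2 to compound 4 (0.20 log units; within the scatter) will be small, most likely toward a somewhat higher number. Compound 4 is estimated at 30000 nM, with a range from 9000 nM to 120000 nM.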

Compound 4, half-maximal inhibitory concentration: 41000 nM
Compound 4: middle estimate off by 1.4-fold (0.14 log units), on the low side; measured number inside the range.
By their numbers in this assay, from the lowest: compound 2; then compounds 4 and 3 (each within the scatter of the next); then compound 1.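

Compound 4 brings the first branched chain at this position, on a saturated chain carbon bound to an amine nitrogen, and in this assay the change gives a 2.2-fold higher number from compound 2 to compound 4 (0.33 log units; beyond the scatter). The step is modest, like those among the straight chains, so branching here does not take the number outside the range those chains already span, yet it is large enough to stand beyond the scatter. Nothing measured here explains the step, and no outside evidence bears on it.

The compounds shown leave open how much of the step belongs to branching and how much to the shorter chain, since pentyl giving way to isobutyl changes both at once. They also leave open how a straight butyl chain, a cyclopentyl ring or a chain ending in a hydroxyl group would read at this position.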